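Replacing 4-methylpiperidin-1-yl in compound 3 with dimethylamino

A few compounds are considered here, and "the series" means these few. Any claim that something is new, unique, unknown or untested is made for them only; others in the source may bear on it.

Measured in a functional assay on MDA-MB-231 cells (Homo sapiens) for cytotoxicity, read by MTT assay, with a stated time of 72 h; on this read-out lower numbers stand for stronger inhibition and higher numbers for weaker inhibition:
compound 1 `CC1CCN(Cc2ccc3nc(NC(=O)N/N=C/c4cn(Cc5ccc(Cl)cc5Cl)c5ccccc45)sc3c2)CC1` gives 3140 nM
compound 2 `CC1CCN(Cc2ccc3nc(NC(=O)N/N=C/c4cn(Cc5cccc(Cl)c5)c5ccccc45)sc3c2)CC1` gives 2110 nM
compound 3 `Cc1ccc(Cn2cc(/C=N/NC(=O)Nc3nc4ccc(CN5CCC(C)CC5)cc4s3)c3ccccc32)cc1` gives 1140 nM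

Two steps place compound 3 on these numbers: a 2.8-fold lower number from compound 1 to compound 3 (0.44 log units; beyond the scatter) and a 1.9-fold lower number from compound 2 to compound 3 (0.27 log units; within the scatter). It therefore sits clearly under one neighbour and level with the other.

Compound 4 `Cc1ccc(Cn2cc(/C=N/NC(=O)Nc3nc4ccc(CN(C)C)cc4s3)c3ccccc32)cc1` carries dimethylamino in place of 4-methylpiperidin-1-yl on a saturated chain carbon bound to an aromatic carbon. Going by the values given here, no measured step touches this place. All three, a 1.5-fold lower number from compound 1 to compound 2 (0.17 log units; within the scatter) included, change the group on a saturated chain carbon bound to an aromatic nitrogen, so they offer only a guide to size. The largest of them, a 2.8-fold lower number from compound 1 to compound 3 (0.44 log units; beyond the scatter), is modest. A step of similar modest size is expected here, leaning only tentatively towards a higher number, since the data show no direction for this change. The expected move is a 1.6-fold higher number from compound 3 to compound 4 (0.20 log units; within the scatter). For compound 4 the estimated value is 1800 nM, with an expected range from 700 nM to 4500 nM.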

Compound 4, half-maximal inhibitory concentration: 1220 nM
Compound 4: middle estimate off by 1.5-fold (0.17 log units), on the high side; low and high end bracket the measured number.
By their numbers in this assay, from the lowest: compounds 3, 4, 2 and 1 (each within the scatter of the next, the first and the last beyond it).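

Across this assay, the step at this place, on a saturated chain carbon bound to an aromatic carbon, is a 1.1-fold higher number from compound 3 to compound 4 (0.03 log units; within the scatter), and it lies within the scatter. With the 4-methylphenyl group held constant, the read-out therefore stays level when the 4-methylpiperidin-1-yl ring of 7 heavy atoms gives way to the ringless dimethylamino group of 3 heavy atoms, so in this pair the ring and its methyl are not needed to hold the value. No measurement is available that would explain this result.

Going by these compounds, it remains open whether dimethylamino would read the same alongside the 3-chlorophenyl group of compound 2 or the 2,4-dichlorophenyl group of compound 1. On these data alone, it also remains open how a morpholine, a primary amine or a carboxylic acid would read at this place.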